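Allyl for cyclopropyl on the amide nitrogen of a chlorophenyl dienamide

The source may report more compounds than this note shows. Statements on the series, on what has been measured and on what is new or still open speak of the compounds shown alone.

Two measured compounds frame this step. Compound 1, `C=CCNC(=O)/C(C)=C(\C)c1ccc(Br)cc1`, gives 500 mg/kg in a toxicity assay on the whole organism (strain Icem-CET (SPF Caw)) for cytotoxicity, with Mus musculus as the target; a lower number here means that less compound is needed, a higher number that more compound is needed for the effect. Compound 2, `C/C(C(=O)NC1CC1)=C(/C)c1ccc(Cl)cc1`, reaches only the limit of this assay, > 800 mg/kg, so no number is known for it, and all that can be said is that it sits at the limit of > 800 mg/kg in this assay, at which 1 of the 2 values shown sits. Among the compounds with values here, no step between measured compounds connects these two, since they differ in two places at once; their values alone show that compound 1 falls inside the measured range while compound 2 does not.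

Compound 3, `C=CCNC(=O)/C(C)=C(\C)c1ccc(Cl)cc1`, is the unmeasured partner of compound 2. The change is allyl in place of cyclopropyl on an amide-type nitrogen, in words allyl in place of cyclopropyl on an amide-type nitrogen, so that compound 3 shares its halogen with compound 2 and its amide substituent with compound 1. He therefore expects a step of an at least 1.3-fold lower number from compound 2 to compound 3 (0.12 log units; that floor lies within the scatter) toward a smaller number, of a size that may not exceed the usual scatter. Compound 3 is expected at 600 mg/kg, with a range from 300 mg/kg to 1200 mg/kg, since compound 1, which carries the same allyl group, gives 500 mg/kg.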

Compound 3, dose for half-maximal effect: 90 mg/kg
For compound 3 the middle estimate is 6.7-fold (0.82 log units) above the measured one; measured number below the stated range.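

In this assay, allyl in place of cyclopropyl on an amide-type nitrogen, with the chloro group kept, gives an at least 8.8-fold lower number from compound 2 to compound 3 (0.94 log units; beyond the scatter), so this change on the nitrogen moves the number beyond the scatter even though both groups count the same heavy atoms. From the compounds shown here alone, the true size of that step stays unknown because compound 2 carries a limit of the assay and not a number: the limit of > 800 mg/kg in this assay, at which 1 of the 3 values shown sits. The earlier pair differed in two places at once, and compound 3 now separates them, showing that the halogen also counts on its own, since chloro in place of bromo on an aromatic carbon, with the allyl group kept, gives a 5.6-fold lower number from compound 1 to compound 3 (0.74 log units; beyond the scatter).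

The compounds shown leave open whether the halogen change would act alike with cyclopropyl on the nitrogen, and where a saturated propyl group on that nitrogen would fall, which would tell whether the double bond of the allyl group or merely the open chain goes with the lower number. They also leave open how fluoro or methoxy on the same aromatic carbon would compare with chloro, and what lies behind either step.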